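The source may report more compounds than this note shows. Statements on the series, on what has been measured and on what is new or still open speak of the compounds shown alone.

Of the compounds shown here, three sharing one core have been measured in an assay on isolated protein (Mus musculus) for inhibition of IL15-IL15 receptor (Homo sapiens), read by resazurin assay, with stated times of 30 min and 2.5 days; on this read-out higher numbers stand for weaker inhibition and lower numbers for stronger inhibition. Compound 1 `CC(C)COc1ccc(NC(=O)CCCCCCCSc2nnc(Cc3nn(C)c(=O)c4ccccc34)n2C)cc1` gives 4800 nM, compound 2 `Cn1c(Cc2nn(C)c(=O)c3ccccc23)nnc1SCCCCCCCC(=O)Nc1ccc(O)cc1O` gives 17000 nM, and compound 3 `CC(C)Oc1ccc(NC(=O)CCCCCCCSc2nnc(Cc3nn(C)c(=O)c4ccccc34)n2C)cc1` gives 1100 nM. Compound 3 thus stands at the lowest number of the three: the step of a 4.4-fold lower number from compound 1 to compound 3 (0.64 log units; beyond the scatter) and the step of a 15-fold lower number from compound 2 to compound 3 (1.19 log units; beyond the scatter) both lie beyond the scatter, so compound 3 is the strongest inhibitor among those measured.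

Compound 4 `Cn1c(Cc2nn(C)c(=O)c3ccccc23)nnc1SCCCCCCCC(=O)Oc1ccc(Cl)cc1Cl` is the next compound. It differs from compound 3 in one place: 2,4-dichlorophenoxy in place of (4-isopropoxyphenyl)amino on a carbonyl carbon. The amide nitrogen and its attached hydrogen therefore leave together with the isopropoxy group, and an ester to a dichlorinated ring takes their place.

Among the measured compounds shown here, none of the measured steps changes the amide itself; the steps of a 4.4-fold lower number from compound 1 to compound 3 (0.64 log units; beyond the scatter) and a 15-fold lower number from compound 2 to compound 3 (1.19 log units; beyond the scatter) show only that the group on the amide-type nitrogen moves the number by modest to large amounts, and that the isopropoxy-bearing ring of compound 3 is the most favourable so far. Because compound 3 holds the lowest number 1100 nM and the change is larger than any measured one, a weaker result is expected for compound 4, estimated as a 4.1-fold higher number from compound 3 to compound 4 (0.61 log units; beyond the scatter). Compound 4 is therefore expected at about 4500 nM, within a range from 1200 nM to 17000 nM.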

Compound 4, half-maximal inhibitory concentration: 800 nM
Estimate against measurement, compound 4: 5.6-fold (0.75 log units) above; the measured number lies below the stated range.
By their numbers in this assay, from the lowest: compounds 4 and 3 (each within the scatter of the next); then compound 1; then compound 2.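

In this assay, the step at this carbonyl carbon replaces the amide nitrogen, its hydrogen and the isopropoxy-bearing ring all at once, yet a 1.4-fold lower number from compound 3 to compound 4 (0.14 log units; within the scatter) stays within the scatter, so the earlier picture of a group that moves the number is joined by a much larger exchange that leaves it unchanged. The other two steps set the ester apart from the remaining amides, with a 21-fold lower number from compound 2 to compound 4 (1.33 log units; beyond the scatter) and a 6.0-fold lower number from compound 1 to compound 4 (0.78 log units; beyond the scatter), so among these four compounds an amide nitrogen at this place is not required for the lowest numbers, and compound 3 shows that an ester is not required either. No measurement on hand explains why the two groups give matching numbers.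

The exchange alters the linking atom and the ring substituents together, so these compounds cannot separate the two changes: that would take the 2,4-dichlorophenyl amide or the 4-isopropoxyphenyl ester. Also open, on these data alone, is how a carboxylic acid at this carbonyl carbon, or a longer or shorter saturated chain leading to it, would read in this assay.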